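The compounds below may be only part of what the source reports. "The series", "measured", "known", "first", "only" and "open" are said of these compounds alone.

Compound 1 `O=C(O)CCNC(=O)c1ccc(CN(C(=O)Nc2ccc(OC(F)(F)F)cc2)C2CCN(C(=O)C3CC3)CC2)cc1` gives 1980 nM in an in vitro assay on BHK cells for inhibition of Glucagon receptor (Homo sapiens); on this read-out lower numbers stand for stronger inhibition and higher numbers for weaker inhibition.
Compound 2 `COCCCNC(=O)c1ccc(CN(C(=O)Nc2ccc(OC(F)(F)F)cc2)C2CCC(C(C)(C)C)CC2)cc1` reaches only the limit > 10000 nM in this assay.
Compound 3 `CC(C)(C)C1CCC(N(Cc2ccc(C(=O)NCCCC(=O)O)cc2)C(=O)Nc2ccc(OC(F)(F)F)cc2)CC1` reaches only the limit > 10000 nM in this assay.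

Compound 3 thus stands at the limit of this assay, where two of the three values sit (the limit of > 10000 nM in this assay, at which 2 of the 3 values shown sit). With both ends at that limit, the step that the two limits leave unreadable from compound 2 to compound 3 has no readable size. Compound 4 `CC(C)(C)C1CCC(N(Cc2ccc(C(=O)N3CCCC(C(=O)O)C3)cc2)C(=O)Nc2ccc(OC(F)(F)F)cc2)CC1` differs from compound 3 by 3-carboxypiperidin-1-yl in place of (3-carboxypropyl)amino on a carbonyl carbon. Among the compounds with values here, no measured step touches this change, and the one numerical value, from compound 1, belongs to a compound whose core differs from that of compound 3. The step of a number no higher from compound 3 to compound 4 (the limit leaves the size open) is therefore expected to be none beyond the scatter. Compound 4 is estimated at 10000 nM, between 3000 nM and 30000 nM.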

Compound 4, half-maximal inhibitory concentration: 1000 nM
Compound 4: the middle estimate sits 10-fold (1.00 log units) above what was measured; the whole stated range lies above it.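

On the core shared by compounds 2, 3 and 4, the group on this carbonyl carbon clearly matters: 3-carboxypiperidin-1-yl in place of (3-carboxypropyl)amino gives an at least 10-fold lower number from compound 3 to compound 4 (1.00 log units; beyond the scatter). In place of (3-methoxypropyl)amino, the same ring gives an at least 10-fold lower number from compound 2 to compound 4 (1.00 log units; beyond the scatter). Both sizes are only lower bounds because compounds 2 and 3 stand at a limit: the limit of > 10000 nM in this assay, at which 2 of the 4 values shown sit. Still open, on these data alone, is what a plain piperidin-1-yl group, without the carboxylic acid, would give on this carbonyl carbon. Also open, as far as these compounds go, is whether 4-carboxypiperidin-1-yl would match compound 4.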